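Working notes: amino replaced on the chain of compound 3

The source may report more compounds than this note shows. Statements on the series, on what has been measured and on what is new or still open speak of the compounds shown alone.

Measured in a functional assay on HCT-116 cells (Homo sapiens) for inhibition, read by MTT assay, with a stated time of 48 h; on this read-out higher numbers stand for weaker inhibition and lower numbers for stronger inhibition:
- compound 1 `COc1ccc(N(C)c2nc(C)nc3ccccc23)cc1OCCCCCC[Se]C#N`: 6180 nM
- compound 2 `COc1ccc(N(C)c2nc(C)nc3ccccc23)cc1C(=O)OCCC[Se]C#N`: 720 nM
- compound 3 `COc1ccc(N(C)c2nc(C)nc3ccccc23)cc1OCCN`: 198 nM

Compound 3 stands lowest of the three, at 198 nM in this set. From compound 3 to compound 4 `COc1ccc(N(C)c2nc(C)nc3ccccc23)cc1OCCCCC[Se]C#N` the change is a group of 6 heavy atoms (4 carbon, 1 nitrogen, 1 selenium; no ring) in place of one nitrogen atom, on a saturated chain carbon, two bonds along the chain from an oxygen on an aromatic ring and nothing else. The nearest evidence is a 31-fold lower number from compound 1 to compound 3 (1.49 log units; beyond the scatter) at the same place, which read in reverse points to a higher number. a 3.6-fold lower number from compound 2 to compound 3 (0.56 log units; beyond the scatter) runs the same way but is smaller, and an 8.6-fold lower number from compound 1 to compound 2 (0.93 log units; beyond the scatter) shows how far values move among the selenium-bearing compounds. A large step towards a higher number is therefore expected in this assay for this change. The expected step is an 18-fold higher number from compound 3 to compound 4 (1.25 log units; beyond the scatter) by estimate. Compound 4 is estimated at 3500 nM with an expected range from 1000 nM to 10000 nM overall.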

Compound 4, half-maximal inhibitory concentration: 256 nM
Estimate against measurement, compound 4: 14-fold (1.14 log units) above, and the stated range ends above it.
By their numbers in this assay, from the lowest: compounds 3 and 4 (each within the scatter of the next); then compound 2; then compound 1.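

In this assay the selenium-bearing chain at this place need not cost activity relative to the amino group, with a 1.3-fold higher number from compound 3 to compound 4 (0.11 log units; within the scatter). The large gap of compound 1 therefore does not follow from the selenium-bearing chain as such: the shorter chain alone gives a 24-fold lower number from compound 1 to compound 4 (1.38 log units; beyond the scatter). The ester-linked chain also stands apart, with a 2.8-fold lower number from compound 2 to compound 4 (0.45 log units; beyond the scatter).

No evidence on the cause of these steps is at hand. Open, as far as these compounds go, is whether a still shorter chain, or a thiocyanate in place of the selenium-bearing end, would hold this level.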